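Compound 4: replacing the phenyl of compound 1

A few compounds are considered here, and "the series" means these few. Any claim that something is new, unique, unknown or untested is made for them only; others in the source may bear on it.

Values so far in a functional assay on MCF7 cells (Homo sapiens) for antiproliferative activity, read by sulforhodamine B assay, with a stated time of 72 h; a lower number here means a stronger inhibitor, a higher number a weaker inhibitor
- compound 1 `S=C(NNc1nncc2ccccc12)Nc1ccccc1` gives 47 nM
- compound 2 `COc1ccc(NC(=S)NNc2nncc3ccccc23)cc1` gives 60 nM
- compound 3 `NS(=O)(=O)c1ccc(Nc2nncc3ccccc23)cc1` gives 37 nM

Compound 1 lies in the middle of the three numbers, within the scatter of both compound 2 and compound 3. Compound 4 `NC(=S)NNc1nncc2ccccc12` is still unmeasured and carries hydrogen in place of phenyl on an amide-type nitrogen in comparison with compound 1. Within the data shown here, the only measured step bearing on this is small and within the scatter (a 1.3-fold higher number from compound 1 to compound 2 (0.11 log units; within the scatter)), and it keeps the phenyl. Among the measured compounds shown here, no measured pair tests the loss of that group. In this assay a modest rise in the number is expected (a 2.1-fold higher number from compound 1 to compound 4 (0.33 log units; beyond the scatter)), though no step beyond the scatter also remains possible. The estimate for compound 4 is 100 nM (range 30 nM to 400 nM).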

Compound 4, half-maximal inhibitory concentration: 36 nM
For compound 4 the middle estimate is 2.8-fold (0.44 log units) above the measured one; the measured number falls inside the stated range.
By their numbers in this assay, from the lowest: compounds 4, 3, 1 and 2 (each within the scatter of the next).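

In this assay, hydrogen in place of phenyl on the amide-type nitrogen gives a 1.3-fold lower number from compound 1 to compound 4 (0.12 log units; within the scatter) and so the anilino to amino change stays within the scatter. The phenyl is therefore not required at this position for compound 4 to keep this level of activity, which the methoxy step could not show while the phenyl remained in place. No available measurement explains this result.

As far as these compounds go, whether a methyl, a longer alkyl chain or a carboxylic acid on this nitrogen would keep this level remains open. So does the effect of a carbonyl in place of the thiocarbonyl.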